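Chloro in place of tert-butyl: working notes

A few compounds are considered here, and "the series" means these few. Any claim that something is new, unique, unknown or untested is made for them only; others in the source may bear on it.

Going by the values given here, in a functional assay on DU-145 cells (Homo sapiens) for inhibition, read by CCK-8 assay, with a stated time of 72 h (on this read-out lower numbers stand for stronger inhibition and higher numbers for weaker inhibition), compound 2 (`CC(C)(C)c1ccc(NS(=O)(=O)c2cccc(CCCCCCNC(=O)/C=C/c3cccnc3)c2)cc1`) gives 281 nM, the higher of the two numbers so far, while compound 1 (`Cc1ccc(NS(=O)(=O)c2cccc(CCCCCCNC(=O)/C=C/c3cccnc3)c2)cc1`) gives 34.4 nM. Compound 3 (`O=C(/C=C/c1cccnc1)NCCCCCCc1cccc(S(=O)(=O)Nc2ccc(Cl)cc2)c1`) has chloro in place of tert-butyl on an aromatic carbon, para to a large group: chloro in place of tert-butyl on an aromatic carbon. Among the compounds with values here, the only measured step bearing on this change is an 8.2-fold higher number from compound 1 to compound 2 (0.91 log units; beyond the scatter), where tert-butyl took the place of methyl. A step of similar size towards a lower number is therefore expected in this assay, though one step is thin support. The expected change is a 6.2-fold lower number from compound 2 to compound 3 (0.80 log units; beyond the scatter). Compound 3 is estimated at 45 nM, with an expected range of 15 nM to 130 nM.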

Compound 3, half-maximal inhibitory concentration: 84.4 nM
For compound 3 the middle estimate is 1.9-fold (0.27 log units) below the measured one; measured number inside the range.
By their numbers in this assay, from the lowest: compound 1; then compound 3; then compound 2.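

In this assay, this position on an aromatic carbon, para to a large group, recovers part of the loss seen with tert-butyl when chloro takes its place, with a 3.3-fold lower number from compound 2 to compound 3 (0.52 log units; beyond the scatter). Chloro does not match methyl, however, with a 2.5-fold higher number from compound 1 to compound 3 (0.39 log units; beyond the scatter), so the three groups now fall in the order methyl, chloro, tert-butyl from lowest number to highest. Nothing available accounts for this order. As far as these compounds go, whether methoxy, trifluoromethyl or an amine here would give a number lower than methyl remains open. Also open, from the compounds shown here alone, is whether this order holds on other changes to the shared core.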